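Trifluoromethyl in Place of Methylsulfanyl on the Aniline

The compounds below may be only part of what the source reports. "The series", "measured", "known", "first", "only" and "open" are said of these compounds alone.

Compound 1 `FC(F)(F)c1ccc(Nc2ncnc3sc(Nc4c(Cl)cccc4Cl)nc23)cc1` gives 3 nM in a functional assay on HEK293 cells for antagonist activity at transient receptor potential cation channel subfamily V member 1 (Rattus norvegicus), read by calcium flux; a higher number here means a weaker inhibitor, a lower number a stronger inhibitor. Compound 2 `FC(F)(F)c1ccc(Nc2ncnc3sc(Nc4ccccc4Cl)nc23)cc1` gives 32 nM, and compound 3 `CSc1ccccc1Nc1nc2c(Nc3ccc(C(F)(F)F)cc3)ncnc2s1` gives 26 nM. Among these three, compound 3 stands second highest, with compound 2 nearest and compound 1 furthest; the step of an 8.7-fold higher number from compound 1 to compound 3 (0.94 log units; beyond the scatter) lies beyond the scatter, whereas a 1.2-fold lower number from compound 2 to compound 3 (0.09 log units; within the scatter) lies within it. Compound 4 `FC(F)(F)c1ccc(Nc2ncnc3sc(Nc4ccccc4C(F)(F)F)nc23)cc1` differs from compound 3 by trifluoromethyl in place of methylsulfanyl on an aromatic carbon. The step that bears most directly on this change is a 1.2-fold lower number from compound 2 to compound 3 (0.09 log units; within the scatter), in which exchanging one group at this aromatic carbon for another left the number essentially unchanged. A similar outcome is therefore expected in this assay, with the step of a 1.2-fold higher number from compound 3 to compound 4 (0.06 log units; within the scatter) estimated to stay within the scatter. Compound 4 is estimated at 30 nM, within the range 10 nM to 90 nM.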

Compound 4, half-maximal inhibitory concentration: 37 nM
For compound 4 the middle estimate is 1.2-fold (0.09 log units) below the measured one; measured number inside the range.
By their numbers in this assay, from the lowest: compound 1; then compounds 3, 2 and 4 (each within the scatter of the next).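

Trifluoromethyl now joins chloro and methylsulfanyl at this aromatic carbon without separating from either in this assay: a 1.4-fold higher number from compound 3 to compound 4 (0.15 log units; within the scatter) and a 1.2-fold higher number from compound 2 to compound 4 (0.06 log units; within the scatter) both stay within the scatter. Across these three groups, the number at this position therefore shows no dependence on which one is present. The 2,6-dichlorophenyl of compound 1 remains apart, with a 12-fold higher number from compound 1 to compound 4 (1.09 log units; beyond the scatter) beyond the scatter.

As far as these compounds go, whether an amine or a carboxylic acid at this carbon would read the same remains open. Nothing measured here accounts for the likeness of these three groups.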